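A few compounds are considered here, and "the series" means these few. Any claim that something is new, unique, unknown or untested is made for them only; others in the source may bear on it.

In an assay on isolated protein for inhibition of advanced glycosylation end product-specific receptor (Homo sapiens), read by FRET, with stated times of 30 min and 1 h, tested at 4 uM (on this read-out higher numbers stand for more inhibition at the one concentration tested (going by the name of the read-out) and lower numbers for less inhibition), two compounds have been measured. Compound 1, `Clc1ccc(Oc2ccc3nc(-c4ccc(OC5CCNCC5)cc4)oc3c2)cc1`, gives 20.6%. Compound 2, `CCN(CC)CCCOc1ccc(-c2nc3ccc(Oc4ccc(C(C)(C)C)cc4)cc3o2)cc1`, is reported only as "not active" (no number reported), and no single number describes where it stands on this read-out. Compound 3, `CC(C)(C)c1ccc(Oc2ccc3nc(-c4ccc(OCCCN5CC[C@H](N)C5)cc4)oc3c2)cc1`, has not been measured yet. It differs from compound 2 in one place: 3-aminopyrrolidin-1-yl in place of diethylamino on a saturated chain carbon, three bonds along the chain from an oxygen on an aromatic ring. Within the data shown here, no measured pair shows this particular change, and its size in this assay cannot be read from the other compounds. Given that compound 2 is reported as "not active" (no number reported), the expectation for the step to compound 3 is a small one at most, in either direction, and most likely none beyond the usual scatter. Compound 3 is therefore expected to give 10%, with a likely range from 0% to 30%.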

Compound 3, a percentage reported as inhibition, at one concentration (the size of the read-out at that concentration, not a potency): 54.7%
The estimate for compound 3 lay 44.7 percentage points below the measured number, and the stated range ends below it.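

Among these compounds, compound 2 carries no number, and no step from it to compound 3 can be read. The compounds shown leave open how large a change goes with 3-aminopyrrolidin-1-yl replacing diethylamino. No measurement shown here bears on the reason for the result of compound 3.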